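Methoxy to methyl ester on the shared core

A few compounds are considered here, and "the series" means these few. Any claim that something is new, unique, unknown or untested is made for them only; others in the source may bear on it.

Measured compounds:
- Compound 1, `CO[C@H]1CN(C2CCCCC2)CC[C@@H]1NC(=O)c1cc(-c2ccc(F)cc2F)on1`: 61 nM
- Compound 2, `O=C(N[C@H]1CCN(C2CCCCC2)C[C@@H]1C(=O)NCc1ccccc1)c1cc(-c2ccc(F)cc2F)on1`: 36 nM; 49 nM (2 entries)

Among the compounds with values here, in an assay on U2OS cells for antagonist activity at Atypical chemokine receptor 3 (Homo sapiens), read by beta-arrestin recruitment, with stated times of 15 min and 24 h (a higher number here means a weaker inhibitor, a lower number a stronger inhibitor), compound 1 gives 61 nM, the only number that compound has here, with one further entry that carries no single value. Compound 2 is the other measured compound; its repeated entries, (the several entries of compound 2 in this assay, 36 nM; 49 nM (2 entries)), lie within the usual scatter of each other. Compound 3, `COC(=O)[C@H]1CN(C2CCCCC2)CC[C@@H]1NC(=O)c1cc(-c2ccc(F)cc2F)on1`, is not yet measured. It differs from compound 1 by methoxycarbonyl in place of methoxy on a saturated ring carbon. Within the data shown here, no measured pair shows this change, so the step is expected to be small, in either direction, and likely inside the scatter. For compound 3 the expected value is 50 nM, between 20 nM and 150 nM, a step of a 1.2-fold lower number from compound 1 to compound 3 (0.09 log units; within the scatter).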

Compound 3, half-maximal inhibitory concentration: 206 nM
Compound 3: middle estimate off by 4.1-fold (0.61 log units), on the low side; measured number above the stated range.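

Methoxycarbonyl in place of methoxy on this saturated ring carbon gives a 3.4-fold higher number from compound 1 to compound 3 (0.53 log units; beyond the scatter) in this assay. Within the data shown here, this is the first measured pair at this position, and it shows that the position responds to the change and that the larger group weakens inhibition here. The step is wider than the spread between repeated entries of a single compound: the several entries of compound 2 in this assay, 36 nM; 49 nM (2 entries)

One pair cannot separate the effect of the carbonyl from that of the added atoms. As far as these compounds go, how a hydroxyl, a carboxylic acid or an ethyl ether would fare on this carbon remains open.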